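A second chloro on a weak compound

This account rests on a few compounds, and the source may have more. Where it says the series, first, only, none or still open, it means among the compounds named here.

Measured in a functional assay on MKN-45 cells (Homo sapiens) for antiproliferative activity, read by MTT assay, with a stated time of 72 h; on this read-out lower numbers stand for stronger inhibition and higher numbers for weaker inhibition:
compound 1 `COc1cc(CCc2ccccc2)cc(OC)c1O`: 1040 nM
compound 2 `COc1cc(CCc2ccccc2Cl)cc(OC)c1O`: 24500 nM
compound 3 `COc1cc(CCc2ccccc2F)cc(OC)c1O`: > 25000 nM

The entry for compound 3 is a limit of the assay, not a number. Of the two exact numbers, compound 2 has the higher at 24500 nM, so it is the weaker of that pair. Compound 4 `COc1cc(CCc2ccc(Cl)cc2Cl)cc(OC)c1O` is new, and its change from compound 2 is chloro in place of hydrogen on an aromatic carbon. Going by the values given here, two measured steps bear on this change, both large: a 24-fold higher number from compound 1 to compound 2 (1.37 log units; beyond the scatter) and an at least 24-fold higher number from compound 1 to compound 3 (1.38 log units; beyond the scatter). Both start from compound 1, which carries no halogen, so they say little about adding a second chloro. No change beyond the scatter is therefore expected in this assay, though a further rise would fit those steps. The expected change is a 1.0-fold higher number from compound 2 to compound 4 (0.01 log units; within the scatter). Compound 4 is estimated at 25000 nM, with an expected range from 7000 nM to 60000 nM.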

Compound 4, half-maximal inhibitory concentration: 4460 nM
Estimate against measurement, compound 4: 5.6-fold (0.75 log units) above; the measured number lies below the stated range.
By their numbers in this assay, from the lowest: compound 1; then compound 4; then compound 2. At a limit, above all of these: compound 3.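

In this assay, a second chloro, meta to the first chloro group and para to a large group, gives a 5.5-fold lower number from compound 2 to compound 4 (0.74 log units; beyond the scatter). Going by these compounds alone, the earlier steps all started from compound 1 and showed halogens only raising the number, so this is the first sign that a chloro can lower it on this ring. Compound 3 stands at a limit of the assay, and the starting point of this step, compound 2, lies close to that limit: the limit of > 25000 nM in this assay, at which 1 of the 4 values shown sits.

As far as these compounds go, whether a chloro at this place would lower the number without the first chloro stays open. So does the effect of an amine or a methoxy group there.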